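The compounds below may be only part of what the source reports. "The series", "measured", "known", "first", "only" and "open" are said of these compounds alone.

For the measured compounds named here, compound 2 `C[C@@H](O[C@H]1CN2C(=O)C=C(c3cc[nH]c(=O)c3)CC2[C@@H]1c1ccc(F)cc1)c1cc(C(F)(F)F)cc(C(F)(F)F)c1` is one of two compounds measured in an assay on CHO cells for displacement of a labelled ligand from Substance-P receptor (Homo sapiens); a higher number here means a weaker inhibitor, a lower number a stronger inhibitor. In this assay compound 2 gives 0.27 nM, the lowest of the two numbers shown. The nearest is compound 1 `C[C@@H](O[C@H]1CN2C(=O)C=C(c3ccc(C#N)cc3)CC2[C@@H]1c1ccc(F)cc1)c1cc(C(F)(F)F)cc(C(F)(F)F)c1`, which in this assay gives 1.8 nM; the step from compound 1 to compound 2 is a 6.7-fold lower number from compound 1 to compound 2 (0.82 log units; beyond the scatter), a modest change that went with the exchange of an all-carbon aromatic ring for a ring holding a hetero atom.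

Compound 3 `C[C@@H](O[C@H]1CN2C(=O)C=C(c3ccc[n+]([O-])c3)CC2[C@@H]1c1ccc(F)cc1)c1cc(C(F)(F)F)cc(C(F)(F)F)c1` keeps the shared core and differs from compound 2 only in that ring: a group of 7 heavy atoms (5 carbon, 1 nitrogen, 1 oxygen; one six-membered aromatic ring with 1 hetero atom) in place of a group of 7 heavy atoms (5 carbon, 1 nitrogen, 1 oxygen; one six-membered aromatic ring with 1 hetero atom), on a double-bonded ring carbon. The two structures hold the same atoms, joined differently, and the part that leaves carries a hydrogen-bond donor while the part that enters carries none.

Going by the values given here, no measured step in this set covers such a rearrangement; the only step known, from compound 1 to compound 2, concerns a different exchange and so offers no direct guide. The expectation for compound 3 is therefore a small rise in the number, a 2.6-fold higher number from compound 2 to compound 3 (0.41 log units; beyond the scatter), with wide uncertainty. Compound 3 is estimated at 0.7 nM, with a range from 0.15 nM to 3 nM.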

Compound 3, half-maximal inhibitory concentration: 0.15 nM
The estimate for compound 3 lay 4.7-fold (0.67 log units) above the measured number; measured number inside the range.
By their numbers in this assay, from the lowest: compounds 3 and 2 (each within the scatter of the next); then compound 1.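

In this assay, moving the ring nitrogen and oxygen into a new arrangement gives a 1.8-fold lower number from compound 2 to compound 3 (0.26 log units; within the scatter), even though the part that enters has 0 hydrogen-bond donors; among these two compounds, then, the amide hydrogen of compound 2 is not required for a number at this level. Set against the all-carbon ring with its nitrile, the same ring gives a 12-fold lower number from compound 1 to compound 3 (1.08 log units; beyond the scatter), so at this double-bonded ring carbon, both six-membered aromatic rings with a hetero atom now stand beyond the scatter from compound 1, and the earlier gain is no longer tied to one arrangement of atoms. Nothing shown here explains why the two arrangements give such similar numbers or why both differ from compound 1.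

A plain pyridine ring without the oxygen, and a plain phenyl ring without the nitrile, would help show how much the ring atom and each attached group contribute. As far as these compounds go, it also remains open whether an amine or a carboxylic acid on this ring would keep the number in the same range.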